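Fluorine at the Para Position of a Spiro Scaffold

A few compounds are considered here, and "the series" means these few. Any claim that something is new, unique, unknown or untested is made for them only; others in the source may bear on it.

For the measured compounds named here, in a functional assay on the whole organism (strain Wister albino) for inhibition, with Rattus norvegicus as the target, read by paw edema, with stated times of 1 h and 4 h, at a dose of 50 mg/kg by the intraperitoneal route (a lower number here means less inhibition, a higher number more inhibition at the dose given (going by the name of the read-out)), compound 2 `CN1C[C@@H](c2ccccc2)[C@@]2(Cc3ccccc3C2=O)[C@@]12C(=O)Nc1ccccc12` gives 39.3%, the higher of the two numbers known, while compound 1 `Cc1ccc([C@@H]2CN(C)[C@]3(C(=O)Nc4ccccc43)[C@]23Cc2ccccc2C3=O)cc1` gives 17.1%. Going by the values given here, the only step measured, a number 22.2 percentage points higher from compound 1 to compound 2 (beyond the scatter), shows that the substituent on this aromatic carbon matters, since removing the methyl raised inhibition by a modest amount beyond the scatter. Compound 3 `CN1C[C@@H](c2ccc(F)cc2)[C@@]2(Cc3ccccc3C2=O)[C@@]12C(=O)Nc1ccccc12` differs from compound 2 by fluoro in place of hydrogen on an aromatic carbon. Among the compounds with values here, no measured pair shows a fluoro entering at this place, so the step from methyl to hydrogen is the only guide, and it suggests that adding a group back at this carbon could lower inhibition, though fluorine is far smaller than methyl. Compound 3 is therefore expected to sit slightly below compound 2, a step of a number 7.3 percentage points lower from compound 2 to compound 3 (within the scatter) that may not exceed the scatter. Compound 3 is estimated at 32%, within a range from 18% to 46%.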

Compound 3, a percentage reported as inhibition, in the whole organism at one dose (the size of the read-out at that dose, not a potency): 21.8%
The estimate for compound 3 lay 10.2 percentage points above the measured number, within the range that was stated.
By their numbers in this assay, from the lowest: compounds 1 and 3 (each within the scatter of the next); then compound 2.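

Fluoro in place of hydrogen on this aromatic carbon gives a number 17.5 percentage points lower from compound 2 to compound 3 (beyond the scatter) in this assay, so the loss of inhibition seen with methyl is not confined to that one group: a single fluorine atom here is also enough to produce a drop beyond the scatter. Fluoro in place of methyl gives a number 4.7 percentage points higher from compound 1 to compound 3 (within the scatter), so the two substituted compounds cannot be told apart in this read-out, and compound 2, with hydrogen at this carbon, stands above both. Nothing among the data shown explains why either substituent lowers inhibition.

On these data alone, how a hydroxyl, an amine or a carboxylic acid at this carbon would compare with compound 2 remains open. Also open, as far as these compounds go, is whether chlorine would follow fluoro and methyl, or whether fluoro would have the same effect on another carbon of this ring.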